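A few compounds are considered here, and "the series" means these few. Any claim that something is new, unique, unknown or untested is made for them only; others in the source may bear on it.

Of the compounds shown here, three with one shared core have been tested in a functional assay on MKN-45 cells (Homo sapiens) for cytotoxicity, read by MTT assay, with a stated time of 72 h; on this read-out higher numbers stand for weaker inhibition and lower numbers for stronger inhibition. Compound 1 `COc1cc2c(Oc3ccc(NC(=O)c4nn(-c5ccc(Br)cc5)c(=O)c5ccccc45)cc3F)ccnc2cc1OCCCN1CCCC1` gives 230 nM. Compound 2 `COc1cc2c(Oc3ccc(NC(=O)c4nn(-c5ccc(Br)cc5)c(=O)c5ccccc45)cc3F)ccnc2cc1OCCCN1CCN(C)CC1` carries a 4-methylpiperazin-1-yl group in place of the pyrrolidin-1-yl group of compound 1. In this assay compound 2 gives 350 nM; the step of a 1.5-fold higher number from compound 1 to compound 2 (0.18 log units; within the scatter) shows that this exchange of the amine at the end of the chain leaves the result essentially where it was. Compound 3 `COc1cc2c(Oc3ccc(NC(=O)c4nn(-c5ccccc5F)c(=O)c5ccccc45)cc3F)ccnc2cc1OCCCN1CCCCC1` gives 350 nM, level with compound 2 at the digits printed, and together with compound 2 it gives the highest of the three numbers, with compound 1 the furthest away, though within the scatter.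

Compound 4 `COc1cc2c(Oc3ccc(NC(=O)c4nn(-c5ccc(Br)cc5)c(=O)c5ccccc45)cc3F)ccnc2cc1OCCCN1CCCCC1` is the next compound. It differs from compound 3 in a single place: 4-bromophenyl in place of 2-fluorophenyl on an aromatic nitrogen. Within the data shown here, no measured pair changes only this group; compound 1 and compound 3 differ both here and in the amine, so their values alone cannot separate the two changes. Among the measured compounds shown here, the one measured step, from compound 1 to compound 2, concerns the amine and stays within the scatter. With no evidence for a shift, compound 4 is expected to stay close to compound 3, a step of a 1.2-fold lower number from compound 3 to compound 4 (0.07 log units; within the scatter) that means no change beyond the scatter.

Compound 4 is therefore estimated at 300 nM, within a range from 130 nM to 700 nM.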

Compound 4, half-maximal inhibitory concentration: 500 nM
Beside the measured number, compound 4's estimate is 1.7-fold (0.22 log units) below it; the range from low to high includes it.
By their numbers in this assay, from the lowest: compounds 1, 2, 3 and 4 (each within the scatter of the next, the first and the last beyond it).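

In this assay, among these compounds, the group on the aromatic nitrogen can now be read on its own for the first time: with the piperidin-1-yl amine held fixed, 4-bromophenyl in place of 2-fluorophenyl gives a 1.4-fold higher number from compound 3 to compound 4 (0.15 log units; within the scatter) and so shows that this exchange has no effect that can be told from assay noise. Among the compounds shown here, with 4-bromophenyl held fixed, three amines at the end of the chain can now be set side by side: piperidin-1-yl in place of 4-methylpiperazin-1-yl gives a 1.4-fold higher number from compound 2 to compound 4 (0.15 log units; within the scatter) and does not separate that pair, whereas piperidin-1-yl in place of pyrrolidin-1-yl gives a 2.2-fold higher number from compound 1 to compound 4 (0.34 log units; beyond the scatter) as the first step here to pass the scatter, and only modestly. No supporting measurement is available to explain this small gap between the two amines.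

For the compounds shown here, the one exchange on the aromatic nitrogen alters both the halogen and where it sits, so a 4-fluorophenyl group would be needed to tell those two changes apart. Also open, on these data alone, is how a morpholin-4-yl or dimethylamino group at the end of the chain would compare with these three amines.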